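Alkyl benzoate esters of the shared core: cytotoxicity notes

The source may report more compounds than this note shows. Statements on the series, on what has been measured and on what is new or still open speak of the compounds shown alone.

Compound 2 `CC(C)(C)c1ccc(C(=O)OCCCc2cn(-c3ccnc4cc(Cl)ccc34)nn2)cc1` stands only at a limit of the assay: in an ADME assay on HepG2 cells (Homo sapiens) for cytotoxicity, read by MTT assay, with a stated time of 24 h (a higher number here means that more compound is tolerated, a lower number that less compound is tolerated), compound 2 gives > 2230000 nM. Compound 1 `CCc1ccc(C(=O)OCCCc2cn(-c3ccnc4cc(Cl)ccc34)nn2)cc1` likewise shows only a limit, giving > 2550000 nM in this assay. The step from compound 1 to compound 2, a step that the two limits leave unreadable from compound 1 to compound 2, is thus not readable in size or direction. Compound 3 `Cc1ccc(C(=O)OCCCc2cn(-c3ccnc4cc(Cl)ccc34)nn2)cc1` is not yet measured; it differs from compound 2 by methyl in place of tert-butyl on an aromatic carbon. Within the data shown here, no measured step speaks readably to this change; what is known is that both measured values sit at limits, the limit of > 2230000 nM in this assay, at which 1 of the 2 values shown sits, and (the limit of > 2550000 nM in this assay, at which 1 of the 2 values shown sits). In this assay compound 3 is expected to give 2500000 nM (range 800000 nM to 8000000 nM). The step that the limit leaves unreadable from compound 2 to compound 3 is expected to stay within the scatter.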

Compound 3, half-maximal cytotoxic concentration: > 2460000 nM
Compound 3: no number, only a limit; the forecaster's own chance of this, stated with the estimate: 85%; the middle value lies beyond the limit too.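

In this assay, among these compounds, compound 1, compound 2 and compound 3 all stand only at limits, and no step among them can be read. The compounds shown leave open at what concentration these esters become cytotoxic, and whether the alkyl group matters.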